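Swapping fluoro for trifluoromethyl on a second core

The source may report more compounds than this note shows. Statements on the series, on what has been measured and on what is new or still open speak of the compounds shown alone.

Of the compounds shown here, three have been tested in a functional assay on VCaP cells (Homo sapiens) for antiproliferative activity, read by propidium iodide staining, with a stated time of 96 h; a lower number here means a stronger inhibitor, a higher number a weaker inhibitor. Compound 1 `CC(O)(CSc1ccc(F)cc1)C(=O)Nc1cccc(S(F)(F)(F)(F)F)c1` gives 21900 nM, and compound 2 `CC(O)(CSc1ccc(C(F)(F)F)cc1)C(=O)Nc1cccc(S(F)(F)(F)(F)F)c1` gives 27300 nM. These two differ in one place: trifluoromethyl in place of fluoro on an aromatic carbon. The step that this change made is a 1.2-fold higher number from compound 1 to compound 2 (0.10 log units; within the scatter).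

Compound 3 `CC(O)(CS(=O)(=O)c1ccc(F)cc1)C(=O)Nc1ccc(S(F)(F)(F)(F)F)cc1` has a different core; the difference between the cores of compound 1 and compound 3 is not broken down here. In this assay compound 3 gives 34200 nM.

Compound 4 `CC(O)(CS(=O)(=O)c1ccc(C(F)(F)F)cc1)C(=O)Nc1ccc(S(F)(F)(F)(F)F)cc1` has not yet been measured. It differs from compound 3 in the same way that compound 2 differs from compound 1: trifluoromethyl in place of fluoro on an aromatic carbon. Because the step of a 1.2-fold higher number from compound 1 to compound 2 (0.10 log units; within the scatter) stayed within the scatter, the same change on the core of compound 3 is expected to move the number little, and the step of a 1.2-fold higher number from compound 3 to compound 4 (0.07 log units; within the scatter) is the expectation. For compound 4 the estimated value in this assay is 40000 nM, with an expected range from 20000 nM to 80000 nM.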

Compound 4, half-maximal inhibitory concentration: 27700 nM
The estimate for compound 4 lay 1.4-fold (0.16 log units) above the measured number; the measured number falls inside the stated range.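

In this assay, putting trifluoromethyl in place of fluoro gives a 1.2-fold lower number from compound 3 to compound 4 (0.09 log units; within the scatter). Set beside the same change on the core of compound 1, the step stays small on both cores, and the two steps cannot be told apart: the same change on two cores in this assay, a 1.2-fold higher number (0.10 log units; within the scatter) from compound 1 to compound 2 and a 1.2-fold lower number (0.09 log units; within the scatter) from compound 3 to compound 4, 1.5-fold (0.19 log units) apart, within the scatter of two such steps. This shows that, for these two pairs, the change carried from one core to the other without a step that stands out from the scatter, but it does not show that the change has a real effect in either direction, or that it would stay this small on a further core.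

The compounds shown leave open what a group of another kind, such as an amine or a carboxylic acid, would do in place of the fluoro. They also leave open what the difference between the cores of compound 1 and compound 3 does on its own, as those two compounds differ in more than one place.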